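Halogen swap on the pendant aryl of the fused series

The source may report more compounds than this note shows. Statements on the series, on what has been measured and on what is new or still open speak of the compounds shown alone.

Measured so far:
compound 1, `COc1ccc(/C=C2\CCCc3c2nc(N)c(C#N)c3-c2ccc(OC)c(OC)c2)cc1OC`, 84.2%
compound 2, `COc1ccc(/C=C2\CCCC3C2=NN(C2=NC(=O)/C(=C/c4ccc(OC)c(OC)c4)S2)C3c2ccc(OC)cc2)cc1`, 75.8%
compound 3, `COc1ccc(/C=C2\CCCC3C2=NN(C2=NC(=O)/C(=C/c4ccc(Cl)cc4)S2)C3c2ccc(OC)cc2)cc1`, 84%

All three numbers come from a functional assay on Ehrlich cells (Mus musculus) for cytotoxicity, read by trypan blue exclusion, with a stated time of 24 h, tested at 100 uM; a higher number here means a stronger effect of the compound at the concentration tested, a lower number a weaker effect. Compound 3 sits close to both other compounds: its gap to compound 1 and its gap to compound 2 are each within the scatter, so the three measured compounds cannot be separated by this read-out.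

For the measured compounds named here, the only single-point step available is a number 8.2 percentage points higher from compound 2 to compound 3 (within the scatter), which exchanges one pendant aryl for another at the same position and leaves the number essentially where it was.

Compound 4, `COc1ccc(/C=C2\CCCC3C2=NN(C2=NC(=O)/C(=C/c4ccc(Br)cc4)S2)C3c2ccc(OC)cc2)cc1`, is the next member. It differs from compound 3 by bromo in place of chloro on an aromatic carbon, that is, 4-chlorophenyl to 4-bromophenyl. Going by the values given here, no measured pair shows a bromo for chloro exchange, so the step from compound 2 to compound 3 is the nearest precedent: a larger change at the same position that stayed within the scatter. A smaller change is therefore expected to do the same, with no movement beyond the scatter in either direction.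

The estimated step is a number 2 percentage points lower from compound 3 to compound 4 (within the scatter), expected to be within the scatter. Compound 4 is therefore estimated at 82%, with a range from 70% to 92%.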

Compound 4, a percentage reported as activity, at one concentration (the size of the read-out at that concentration, not a potency): 81.6%
Beside the measured number, compound 4's estimate is 0.4 percentage points above it, within the range that was stated.
By their numbers in this assay, from the lowest: compounds 2, 4, 3 and 1 (each within the scatter of the next).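

In this assay the exchange on the pendant aryl itself reads as a number 2.4 percentage points lower from compound 3 to compound 4 (within the scatter) and gives the first direct view of bromo in place of chloro on an aromatic carbon of this series. Read together with a number 5.8 percentage points higher from compound 2 to compound 4 (within the scatter) at the same position, it shows that 4-chlorophenyl, 4-bromophenyl and 3,4-dimethoxyphenyl cannot be told apart by this read-out, so neither the choice of halogen nor the exchange of either halogenated aryl for the dimethoxy-substituted one gives a step beyond the scatter. No supporting measurement bears on these readings or on what lies behind them.

The compounds shown leave open whether any group on this aryl separates from the others beyond the scatter, for instance a carboxylic acid, a primary amine or a longer alkoxy chain in place of the halogen. They also leave open whether the halogenated pair would stay together in a full concentration series, since a single-concentration percentage gives the size of the effect at that concentration and not a potency.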